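A few compounds are considered here, and "the series" means these few. Any claim that something is new, unique, unknown or untested is made for them only; others in the source may bear on it.

Among the measured compounds shown here, only two compounds with this core have been measured so far in a functional assay on HT-29 cells (Homo sapiens) for antiproliferative activity, read by MTT assay, with a stated time of 72 h; a lower number here means a stronger inhibitor, a higher number a weaker inhibitor. Compound 1 `CNc1nc(-c2cc(OC)c(OC)c(OC)c2)c(-c2ccc3ccccc3c2)s1` gives 38.2 nM, and compound 2 `COc1cc(-c2nc(N(C)C)sc2-c2ccc3ccccc3c2)cc(OC)c1OC` gives 729 nM, so compound 2 carries the higher number of the pair and is the weaker inhibitor. For the measured compounds named here, the one measured step, a 19-fold higher number from compound 1 to compound 2 (1.28 log units; beyond the scatter), is large and lies beyond the scatter, but it concerns only the substitution on the nitrogen.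

Compound 3 `CCOc1ccc(-c2sc(N(C)C)nc2-c2cc(OC)c(OC)c(OC)c2)cc1` keeps the dimethylamino group of compound 2 and changes a different place: 4-ethoxyphenyl in place of naphthalen-2-yl on an aromatic carbon. This puts 4-ethoxyphenyl in place of naphthalen-2-yl on an aromatic carbon, next to the ring sulfur. Going by the values given here, no measured compound shows what happens at this position, so the step of a 19-fold higher number from compound 1 to compound 2 (1.28 log units; beyond the scatter) gives neither a size nor a direction for the new change. With no such evidence, the value of compound 2, 729 nM, remains the best starting point, and no shift beyond the scatter is predicted. The expected change is a 1.6-fold lower number from compound 2 to compound 3 (0.21 log units; within the scatter), a small step with real uncertainty around it. For compound 3, the estimated value in this assay is 450 nM, with an expected range of 80 nM to 2500 nM.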

Compound 3, half-maximal inhibitory concentration: 6030 nM
The estimate for compound 3 lay 13-fold (1.13 log units) below the measured number; the measured number lies above the stated range.
By their numbers in this assay, from the lowest: compound 1; then compound 2; then compound 3.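

This position, an aromatic carbon next to the ring sulfur, clearly affects the result in this assay. Placing 4-ethoxyphenyl there in place of naphthalen-2-yl gives an 8.3-fold higher number from compound 2 to compound 3 (0.92 log units; beyond the scatter), a step beyond the scatter, so compound 2 is the stronger inhibitor of this pair and the group at this position is not interchangeable. The step changes more than one thing at once, since the group that leaves has two six-membered aromatic rings of carbon only, while the group that enters has one such ring and carries an oxygen, and nothing available on these compounds explains the weaker result.

The compounds shown do not separate the effect of losing the second ring from that of adding the ethoxy group, a question that a plain phenyl ring or a propoxy chain in place of the ethoxy could help to address. They also leave open whether the same exchange would have a similar effect with the nitrogen substitution of compound 1.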